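Swapping a methoxy for 4-fluorophenyl on a terpene-styrene scaffold

The compounds below may be only part of what the source reports. "The series", "measured", "known", "first", "only" and "open" are said of these compounds alone.

Compound 1 has the structure `C=C[C@@](C)(/C=C/c1ccc(OC)cc1)CCC=C(C)C`. In a functional assay on HepG2 cells (Homo sapiens) for cytotoxicity, with a stated time of 72 h (a lower number here means that less compound is needed, a higher number that more compound is needed for the effect), compound 1 gives > 52000 nM, which is a limit of the assay rather than a number. Compound 2, built on the same core as `COc1ccc(/C=C/[C@@](C)(/C=C/c2ccc(O)c(/C=C/C(=O)OC(C)(C)C)c2)CCC=C(C)C)cc1`, is the second compound on record; in this assay compound 2 gives > 52000 nM, again a limit. Thus (the limit of > 52000 nM in this assay, at which 2 of the 2 values shown sit). Compound 3, with the structure `C=C[C@@](C)(/C=C/c1ccc(-c2ccc(F)cc2)cc1)CCC=C(C)C`, is the untested partner of compound 1 and differs from it by 4-fluorophenyl in place of methoxy on an aromatic carbon. Going by the values given here, with no measured step between any two compounds to lean on, the expectation is a modest change at most: the step from compound 1 to compound 3 is estimated as an at least 1.4-fold lower number from compound 1 to compound 3 (0.17 log units; that floor lies within the scatter), toward a somewhat lower number. Compound 3 is therefore expected to give about 35000 nM in this assay, within a range of 12000 nM to 100000 nM.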

Compound 3, half-maximal effective concentration: > 52000 nM
Compound 3 gave a limit, no number; the forecaster's own chance of this, stated with the estimate: 55%; middle value at least 1.4-fold (0.17 log units) from the limit.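

No step can be read between compound 1 and compound 3, because both sit at the same limit, which is not a number: the limit of > 52000 nM in this assay, at which 3 of the 3 values shown sit.

The compounds shown leave open whether 4-fluorophenyl in place of methoxy changes the result at all in this assay.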